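Aryl for alkyl on the alkyne: compound 3 outlook

The source may hold more compounds than are shown below. What is called first, only, known or untested is meant among the compounds shown, and "the series" means these compounds.

Going by the values given here, compound 1 `CCCCC#Cc1cn(C/C=C\CN2C(=O)c3ccccc3C2=O)c(=O)[nH]c1=O` stands at the top of the two numbers measured so far. In a functional assay on HepG2 cells (Homo sapiens) for antiproliferative activity, read by MTT assay, with a stated time of 3 days (a lower number here means a stronger inhibitor, a higher number a weaker inhibitor), compound 1 gives 17000 nM. Compound 2 `O=C1c2ccccc2C(=O)N1C/C=C/Cn1cc(C#CCCc2ccccc2)c(=O)[nH]c1=O` gives 7300 nM in this assay, and the gap between the two lies beyond the usual scatter, so compound 2 is the stronger inhibitor of the pair. Among the compounds with values here, no pair of measured compounds differs in a single place, so no measured step is available to anchor the move to compound 3; its two values are all the series offers.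

Compound 3 `Cc1ccc(C#Cc2cn(C/C=C\CN3C(=O)c4ccccc4C3=O)c(=O)[nH]c2=O)cc1` differs from compound 1 in one place: 4-methylphenyl in place of butyl on a triple-bonded carbon. Everything else in compound 1 is kept.

Compound 2, with its 7300 nM, shows that the series can reach lower numbers than compound 1, but without a counted difference for that pair it gives no direction for an aryl group on the triple-bonded carbon. The expected step from compound 1 to compound 3 is therefore a modest lowering of the number, a 1.9-fold lower number from compound 1 to compound 3 (0.28 log units; within the scatter), which may well stay within the scatter. Compound 3 is estimated at 9000 nM, with a range from 3000 nM to 27000 nM.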

Compound 3, half-maximal inhibitory concentration: 68000 nM
Beside the measured number, compound 3's estimate is 7.6-fold (0.88 log units) below it; the measured number lies above the stated range.
By their numbers in this assay, from the lowest: compound 2; then compound 1; then compound 3.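

On the triple-bonded carbon, the series now has its first one-place comparison: in this assay, 4-methylphenyl in place of butyl gives a 4.0-fold higher number from compound 1 to compound 3 (0.60 log units; beyond the scatter), a modest step towards a weaker inhibitor that lies beyond the scatter. This shows that the number responds to the group at this position, and that this aromatic ring offers no gain over the butyl chain of the compound 1 scaffold. Going by these compounds alone, no measurement available here accounts for the rise, and the single step cannot separate the effect of the ring from that of its methyl group or of the change from 4 to 7 heavy atoms.

The compounds shown leave open whether plain phenyl would sit with compound 1 or with compound 3, and whether a methoxy group or a chlorine in place of the methyl on the ring would move the number at all. On the alkyl side, a longer chain such as hexyl, or a butyl chain ending in an amine or a carboxylic acid, would show whether this position tolerates anything beyond the butyl group of compound 1.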